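Amide aryl swap on a quinoline ether: solubility outlook

The compounds below may be only part of what the source reports. "The series", "measured", "known", "first", "only" and "open" are said of these compounds alone.

Measured compounds:
compound 1, `COc1ccc2nc(C)cc(OC3CCN(c4ccccc4)C3=O)c2c1`: 215000 nM
compound 2, `COc1ccc2nc(C)cc(OCC(=O)Nc3cc(C)ccc3C)c2c1`: 45500 nM

Of the compounds shown here, two built on the shared core have been measured in a physicochemical assay for solubility, in phosphate buffer, measured as kinetic solubility, with a stated time of 1 h, at pH 7.4; a higher number here means a more soluble compound, a lower number a less soluble compound. Compound 1 gives 215000 nM in this assay. Compound 2 gives 45500 nM in this assay, the lowest of the two numbers; its nearest neighbour is compound 1, whose number is higher by a margin beyond the usual scatter. The two compounds differ in more than one place, so no single step can be read from them.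

Compound 3, `COc1ccc2nc(C)cc(OCC(=O)Nc3cccnc3)c2c1`, is not yet measured. It is derived from compound 2 by the change (pyridin-3-yl in place of 2,5-dimethylphenyl on an amide-type nitrogen). For the measured compounds named here, no step between measured compounds matches this change, so the expectation rests on the value of compound 2 in this assay alone together with the change itself. In this assay compound 3 is expected to give a number above that of compound 2, with the step of a 3.1-fold higher number from compound 2 to compound 3 (0.49 log units; beyond the scatter) estimated to lie beyond the scatter but short of the level of compound 1. The estimate for compound 3 is 140000 nM, within a range from 55000 nM to 350000 nM.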

Compound 3, solubility: 32000 nM
Compound 3: the middle estimate sits 4.4-fold (0.64 log units) above what was measured, and the stated range ends above it.
By their numbers in this assay, from the lowest: compounds 3 and 2 (each within the scatter of the next); then compound 1.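

In this assay, for the compounds shown here, placing pyridin-3-yl in place of 2,5-dimethylphenyl on an amide-type nitrogen gives a 1.4-fold lower number from compound 2 to compound 3 (0.15 log units; within the scatter) as the first step that can be read at a single place. The leaving group is a six-membered aromatic ring of carbon only with 8 heavy atoms, and the entering group is a six-membered aromatic ring with 1 hetero atom, 6 heavy atoms and 1 hydrogen-bond acceptor, yet the numbers of compound 2 and compound 3 cannot be told apart at this position. No measurement on hand offers an explanation for this result.

Going by these compounds, whether a different group on the same amide-type nitrogen, such as a phenyl ring carrying a carboxylic acid or a dimethylamino group, would produce a step beyond the scatter in this assay remains open. Compound 1 differs from compound 2 and compound 3 in more than one place, so the compounds shown also leave open which of those differences goes with its separate number.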